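This account rests on a few compounds, and the source may have more. Where it says the series, first, only, none or still open, it means among the compounds named here.

Compound 1 `COc1cc(-c2nccn3cc(-c4ccc(N)cc4)nc23)cc(OC)c1OC`, compound 2 `COc1cc(-c2nccn3cc(-c4ccc(F)cc4)nc23)cc(OC)c1OC` and compound 3 `COc1cc(-c2nccn3cc(-c4ccc([N+](=O)[O-])cc4)nc23)cc(OC)c1OC` share one core and differ only in the group carried on one aromatic carbon of the pendant phenyl ring. In a functional assay on HepG2 cells (Homo sapiens) for inhibition, read by MTT assay, with a stated time of 48 h (on this read-out lower numbers stand for stronger inhibition and higher numbers for weaker inhibition), compound 1 gives 252 nM and compound 2 gives 217 nM, a step of a 1.2-fold lower number from compound 1 to compound 2 (0.06 log units; within the scatter). Compound 3 yields no number in this assay, only the limit > 10000 nM, so it stands at the weak end of these measurements, as noted by the limit of > 10000 nM in this assay, at which 1 of the 3 values shown sits. Going to the nitro compound costs a great deal: an at least 39-fold higher number from compound 1 to compound 3 (1.59 log units; beyond the scatter) and an at least 46-fold higher number from compound 2 to compound 3 (1.66 log units; beyond the scatter).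

Compound 4 `COc1cc(-c2nccn3cc(-c4ccc5[nH]ccc5c4)nc23)cc(OC)c1OC` is the next one to be measured in this assay. Compared with compound 3 it shows the change (1H-indol-5-yl in place of 4-nitrophenyl on an aromatic carbon). Both large measured steps point the same way, loss of activity when the nitro group enters, so its removal is expected to reverse that loss, giving an estimated step of an at least 33-fold lower number from compound 3 to compound 4 (1.52 log units; beyond the scatter). Compound 4 is therefore expected to give about 300 nM, with a range from 90 nM to 1500 nM.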

Compound 4, half-maximal inhibitory concentration: 146 nM
For compound 4 the middle estimate is 2.1-fold (0.31 log units) above the measured one; the measured number falls inside the stated range.
By their numbers in this assay, from the lowest: compounds 4, 2 and 1 (each within the scatter of the next). At a limit, above all of these: compound 3.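

In this assay, putting 1H-indol-5-yl in place of 4-nitrophenyl gives an at least 68-fold lower number from compound 3 to compound 4 (1.83 log units; beyond the scatter), and compound 3 counts here only as a limit of the assay: the limit of > 10000 nM in this assay, at which 1 of the 4 values shown sits.

The earlier compounds shown here carried one small group on a single phenyl ring, whereas compound 4 shows that this place also accepts a group of two aromatic rings, with no separation from the 4-fluorophenyl or 4-aminophenyl compounds: a 1.5-fold lower number from compound 2 to compound 4 (0.17 log units; within the scatter) and a 1.7-fold lower number from compound 1 to compound 4 (0.24 log units; within the scatter). Among these four compounds, activity therefore does not require a single phenyl ring, and compound 3 is the only one that falls away.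

From the compounds shown here alone, it remains open whether the hydrogen on the indole nitrogen matters. Going by these compounds, how an indole with a methyl group on that nitrogen, a naphthyl group or a phenyl ring bearing a carboxylic acid would behave in this assay also remains open.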